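A few compounds are considered here, and "the series" means these few. Any claim that something is new, unique, unknown or untested is made for them only; others in the source may bear on it.

Measured so far:
Compound 1 `CCCc1ncc(-c2nc(C(F)(F)F)sc2N2CCN(C(=O)Cn3cnc4cccnc43)[C@H](C)C2)cn1` — 45 nM in an assay on blood for inhibition of C-X-C chemokine receptor type 3 (Homo sapiens), with a stated time of 30 min; on this read-out higher numbers stand for weaker inhibition and lower numbers for stronger inhibition.
Compound 2 `Cc1nc(C)n(CC(=O)N2CCN(c3sc(C(F)(F)F)nc3-c3cnc(OC4CCC4)nc3)C[C@H]2C)n1` — 306 nM in this assay.

Of the two numbers, compound 2 gives the higher one; compound 1 gives the lower number, and the gap between them lies beyond the scatter. Compound 1 and compound 2 differ in more than one place, so no single step can be read from them.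

Compound 3 `CCCc1ncc(-c2nc(C(F)(F)F)sc2N2CCN(C(=O)Cn3nc(C)nc3C)[C@H](C)C2)cn1` is not yet measured. It keeps the core of compound 2 and carries one change: propyl in place of cyclobutyloxy on an aromatic carbon. Compound 3 shares the propyl group with compound 1, but the remaining difference from compound 1 is unmeasured, so the effect of the propyl alone is not known. A moderate step toward a lower number is expected for compound 3, a 2.0-fold lower number from compound 2 to compound 3 (0.31 log units; beyond the scatter), with no confidence that it exceeds the scatter. Compound 3 is therefore estimated at 150 nM, within 50 nM to 450 nM.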

Compound 3, half-maximal inhibitory concentration: 367 nM
For compound 3 the middle estimate is 2.4-fold (0.39 log units) below the measured one; low and high end bracket the measured number.
By their numbers in this assay, from the lowest: compound 1; then compounds 2 and 3 (each within the scatter of the next).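

In this assay, propyl in place of cyclobutyloxy on the aromatic carbon between two ring nitrogen atoms leaves the read-out unchanged (a 1.2-fold higher number from compound 2 to compound 3 (0.08 log units; within the scatter)), so this position accepts either group when the five-membered aromatic ring with 3 hetero atoms is present. With propyl held constant, the group on the saturated chain carbon bound to the carbonyl carbon matters more (an 8.2-fold higher number from compound 1 to compound 3 (0.91 log units; beyond the scatter)), and the two-ring group of compound 1 gives the lower number. No available evidence bears on the reason for either step.

From the compounds shown here alone, whether an amine or a longer alkoxy chain at this position would also leave the read-out unchanged remains open. So does whether cyclobutyloxy matches propyl alongside the two-ring group of compound 1.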